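Two-Limit Series Under a Shared Aryl Triazole Swap

A few compounds are considered here, and "the series" means these few. Any claim that something is new, unique, unknown or untested is made for them only; others in the source may bear on it.

Compound 1 `CCOc1ccccc1-n1nncc1CN1C(=O)C2(C(C#N)=C(N)Oc3c2c2nc4ccccc4nc2c2ccccc32)c2ccccc21` — in a functional assay on HCT-116 cells (Homo sapiens) for antiproliferative activity, read by MTT assay, with a stated time of 48 h (on this read-out lower numbers stand for stronger inhibition and higher numbers for weaker inhibition), compound 1 gives > 50000 nM, a limit of the assay and not a number.
Compound 2 `N#CC1=C(N)Oc2c(c3nc4ccccc4nc3c3ccccc23)C12C(=O)N(Cc1cnnn1-c1ccc([N+](=O)[O-])cc1)c1ccccc12` — in this assay compound 2 gives > 50000 nM, a limit of the assay and not a number.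
Compound 3 `CCOc1ccccc1-n1nncc1CN1C(=O)C2(C(C#N)=C(N)Oc3c(N)cc4nc5ccccc5nc4c32)c2ccccc21` — in this assay compound 3 gives > 50000 nM, a limit of the assay and not a number.

The step from compound 1 to compound 2 is the change (4-nitrophenyl in place of 2-ethoxyphenyl on an aromatic nitrogen). Its size in this assay is a step that the two limits leave unreadable from compound 1 to compound 2, because of the limit of > 50000 nM in this assay, at which 3 of the 3 values shown sit. Within the data shown here, the cores of compound 1 and compound 3 differ, but the difference between the two cores is not broken down here; the two values show only that each compound sits at the same limit.

Compound 4 `N#CC1=C(N)Oc2c(N)cc3nc4ccccc4nc3c2C12C(=O)N(Cc1cnnn1-c1ccc([N+](=O)[O-])cc1)c1ccccc12` is not yet measured. It arises from compound 3 by 4-nitrophenyl in place of 2-ethoxyphenyl on an aromatic nitrogen, the same change as that from compound 1 to compound 2, since both place lines are the same word for word. The earlier step gave no readable size, and compound 3 stands at a limit, so compound 4 is expected to remain at or near that limit, with an estimated step that the limit leaves unreadable from compound 3 to compound 4 in this assay. Compound 4 is therefore expected to give roughly 60000 nM in this assay, within 20000 nM to 200000 nM, most likely reported again as a limit.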

Compound 4, half-maximal inhibitory concentration: > 50000 nM
Compound 4 was reported as a limit; the forecaster's own chance of this, stated with the estimate: 85%; the middle value lies beyond the limit too.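

No size can be read for the step between compound 3 and compound 4 in this assay, because each of the two values is a limit of the assay and not a number: the limit of > 50000 nM in this assay, at which 4 of the 4 values shown sit. The compounds shown leave open whether 4-nitrophenyl in place of 2-ethoxyphenyl changes antiproliferative activity on either core, since none of them gives a readable value in this assay.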